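The source may report more compounds than this note shows. Statements on the series, on what has been measured and on what is new or still open speak of the compounds shown alone.

In a functional assay on MDA-MB-231 cells (Homo sapiens) for cytotoxicity, read by MTT assay, with a stated time of 24 h (a higher number here means a weaker inhibitor, a lower number a stronger inhibitor), compound 1 `CCCCCCCC/C=C\CCCCCCCC(=O)Nc1nnc(S[C@@H]2O[C@H](CO)[C@H](O)[C@H](O)[C@H]2O)s1` gives 43600 nM. For the measured compounds named here, the only other measured compound, compound 2 `C=CCCCCCCCCC(=O)Nc1nnc(S[C@@H]2O[C@H](COC(C)=O)[C@H](OC(C)=O)[C@H](OC(C)=O)[C@H]2OC(C)=O)s1`, gives 60900 nM. These two numbers lie within the usual scatter of each other, so compound 1 cannot be ranked against compound 2. Compound 3 `CCCCCCCCCCCC(=O)Nc1nnc(S[C@@H]2O[C@H](CO)[C@H](O)[C@H](O)[C@H]2O)s1` keeps the core of compound 1 and differs in one place, on a saturated chain carbon, seven bonds along the chain from a carbonyl carbon: butyl in place of dec-1-en-1-yl on a saturated chain carbon, seven bonds along the chain from a carbonyl carbon. Going by the values given here, no measured pair shows what such a change does. The expected step, a 1.1-fold lower number from compound 1 to compound 3 (0.04 log units; within the scatter), stays within the scatter. For compound 3 the estimated value is 40000 nM, with an expected range of 15000 nM to 90000 nM.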

Compound 3, half-maximal inhibitory concentration: 32000 nM
Estimate against measurement, compound 3: 1.3-fold (0.10 log units) above; the measured number falls inside the stated range.
By their numbers in this assay, from the lowest: compounds 3, 1 and 2 (each within the scatter of the next).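

Swapping dec-1-en-1-yl for butyl on a saturated chain carbon, seven bonds along the chain from a carbonyl carbon, gives a 1.4-fold lower number from compound 1 to compound 3 (0.13 log units; within the scatter) in this assay, so this pair cannot be told apart. At this position, the chain end can thus lose its double bond and six carbons with no change beyond the scatter. Nothing available here accounts for this result. Decyl at this position would separate chain length from the double bond, since this change alters both at once. As far as these compounds go, whether a chain ending in an amine or a carboxylic acid would be tolerated as well remains open.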